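Stripping the Amide Substituent from Compound 3

A few compounds are considered here, and "the series" means these few. Any claim that something is new, unique, unknown or untested is made for them only; others in the source may bear on it.

The series shares a core in which a phenyl-bearing urea is fused to a saturated ring carrying a pyrrolidine, with a nitrile on the double-bonded ring carbon; the compounds differ only in what sits on the neighbouring amine nitrogen. In a functional assay on the whole organism (strain albino) for inhibition, with Rattus norvegicus as the target, read by paw edema, with stated times of 1 h and 2 h, at a dose of 20 mmol/kg by the intraperitoneal route (a lower number here means less inhibition, a higher number more inhibition at the dose given (going by the name of the read-out)), compound 1 `N#CC1=C(NCC(=O)N2CCCC2)N(c2ccccc2)C(=O)N2CCCCC(N3CCCC3)C12` gives 49.8%, compound 2 `COc1ccc(N/C=N/C2=C(C#N)C3C(N4CCCC4)CCCCN3C(=O)N2c2ccccc2)cc1` gives 37.2%, and compound 3 `CCOC(=O)C(=O)NC1=C(C#N)C2C(N3CCCC3)CCCCN2C(=O)N1c1ccccc1` gives 83.6%, the highest of the three numbers. The step of a number 33.8 percentage points higher from compound 1 to compound 3 (beyond the scatter) and the step of a number 46.4 percentage points higher from compound 2 to compound 3 (beyond the scatter) both show that what hangs from that nitrogen moves the read-out strongly, while the step of a number 12.6 percentage points lower from compound 1 to compound 2 (beyond the scatter) is smaller.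

Compound 4 `N#CC1=C(N)N(c2ccccc2)C(=O)N2CCCCC(N3CCCC3)C12` is the bare parent: hydrogen in place of (ethoxycarbonyl)carbonyl on an amine nitrogen. Within the data shown here, no measured pair removes a substituent from this nitrogen altogether, so the direction must be inferred. Since the (ethoxycarbonyl)carbonyl group is the feature that lifts compound 3 above compound 1 and compound 2, its loss is expected to cost rather than gain. The expected step is a number 41.6 percentage points lower from compound 3 to compound 4 (beyond the scatter), a large fall in this assay. Compound 4 is therefore estimated at 42%, within a range from 20% to 65%, given how widely the three measured substituents spread.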

Compound 4, a percentage reported as inhibition, in the whole organism at one dose (the size of the read-out at that dose, not a potency): 86.9%
Compound 4: middle estimate off by 44.9 percentage points, on the low side; the whole stated range lies below it.
By their numbers in this assay, from the lowest: compound 2; then compound 1; then compounds 3 and 4 (each within the scatter of the next).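

In this assay, taking the (ethoxycarbonyl)carbonyl group off this amine nitrogen leaves the read-out unresolved from that of the substituted compound, with a number 3.3 percentage points higher from compound 3 to compound 4 (within the scatter) and so no sign that this group is needed for the high number. The bare amino compound also stands well clear of the other two, with a number 37.1 percentage points higher from compound 1 to compound 4 (beyond the scatter) and a number 49.7 percentage points higher from compound 2 to compound 4 (beyond the scatter) in the same assay, so the earlier gaps now read as the substituents of compound 1 and compound 2 going with lower numbers than hydrogen, while the substituent of compound 3 does not. Nothing available here accounts for why these substituents part in this way.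

The compounds shown leave open where the fall sets in, for instance whether a plain methyl or acetyl on this amine nitrogen stays with compound 3 and compound 4 or drops towards compound 1, and whether a carboxylic acid in place of the ethyl ester changes the picture. Since each number comes from a single dose, they also leave open whether compound 3 and compound 4 would stay together at lower doses.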